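The source may report more compounds than this note shows. Statements on the series, on what has been measured and on what is new or still open speak of the compounds shown alone.

Of the compounds shown here, two sharing a central core have been tested in an ADME assay on Huh-7 cells (Homo sapiens) for cytotoxicity; a lower number here means that less compound is tolerated, a higher number that more compound is tolerated. Compound 1 `CN1CCN(CCNCc2cn(-c3ccc(F)cc3F)nc2Cc2ccccc2)CC1` carries one arrangement of groups around that core. In this assay compound 1 reaches only the limit of the measurement, at > 20000 nM, so no number is known for it. Compound 2 `Cc1ccccc1-c1nn(Cc2ccc(F)cc2)cc1CNCCN1CCN(C)CC1` is the closer relative of the compound at hand. In this assay compound 2 also stops at the limit, giving > 20000 nM. Both values therefore sit at the same point, described by the limit of > 20000 nM in this assay, at which 2 of the 2 values shown sit, and nothing separates them. Compound 3 `COc1ccc(-n2cc(CNCCN3CCN(C)CC3)c(-c3ccccc3C)n2)cc1` is not yet measured. It differs from compound 2 in one place: 4-methoxyphenyl in place of 4-fluorobenzyl on an aromatic nitrogen. Going by the values given here, no measured pair of compounds shows a change of this kind, so there is no step to lean on. Compound 2 itself reports only the limit > 20000 nM. The step that the limit leaves unreadable from compound 2 to compound 3 is expected to stay within the scatter of this assay, with no change in direction. Compound 3 is therefore estimated at 30000 nM, with a range from 15000 nM to 80000 nM, and most likely it too will be reported only as a limit.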

Compound 3, half-maximal cytotoxic concentration: > 20000 nM
Compound 3 was reported as a limit (the forecaster's own chance of this, stated with the estimate: 85%); the middle value does not contradict the limit.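

In this assay compound 2 and compound 3 both stop at a limit, so the size of the step between them, 4-methoxyphenyl in place of 4-fluorobenzyl, cannot be read: the limit of > 20000 nM in this assay, at which 3 of the 3 values shown sit. The compounds shown leave open at what concentration each would reach its half-maximal cytotoxic effect, and whether that exchange of groups would shift it.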